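Swapping chloro for bromo on compound 3

A few compounds are considered here, and "the series" means these few. Any claim that something is new, unique, unknown or untested is made for them only; others in the source may bear on it.

In a functional assay on HepG2 cells (Homo sapiens) for cytotoxicity, read by MTT assay, with a stated time of 24 h (a lower number here means a stronger inhibitor, a higher number a weaker inhibitor), compound 3 `O=C1/C(=C/c2ccncc2)CN(S(=O)(=O)c2ccc(Cl)cc2)C/C1=C\c1ccccc1F` gives 5300 nM. That value lies within the scatter of the other two measurements: compound 2 `O=C1/C(=C/c2ccncc2)CNC/C1=C\c1ccccc1F` gives 8200 nM and compound 1 `O=C1/C(=C/c2cccnc2)CN(S(=O)(=O)c2ccc(Br)cc2)C/C1=C\c1ccccc1F` gives 8700 nM, so the three cannot be told apart. The unmeasured compound 4 `O=C1/C(=C/c2ccncc2)CN(S(=O)(=O)c2ccc(Br)cc2)C/C1=C\c1ccccc1F` has bromo in place of chloro on an aromatic carbon. For the measured compounds named here, no measured step makes this exchange. The closest evidence is a 1.5-fold lower number from compound 2 to compound 3 (0.19 log units; within the scatter), where the whole (4-chlorophenyl)sulfonyl group replaces hydrogen on an amine nitrogen in a ring, and that step stays within the scatter. Compound 4 shares the (4-bromophenyl)sulfonyl group with compound 1, which differs elsewhere in the structure and gives 8700 nM. The expected change is a 1.1-fold higher number from compound 3 to compound 4 (0.02 log units; within the scatter), nothing beyond the scatter. For compound 4 the estimated value is 5600 nM, with an expected range from 3000 nM to 10500 nM.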

Compound 4, half-maximal inhibitory concentration: 9300 nM
Compound 4: middle estimate off by 1.7-fold (0.22 log units), on the low side; the range from low to high includes it.
By their numbers in this assay, from the lowest: compounds 3, 2, 1 and 4 (each within the scatter of the next).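

In this assay, for the compounds shown here, this is the first direct reading of the halogen on the aromatic carbon of the aryl sulfonyl group: bromo in place of chloro gives a step within the scatter (a 1.8-fold higher number from compound 3 to compound 4 (0.24 log units; within the scatter)). The (4-bromophenyl)sulfonyl group in place of hydrogen on the ring amine nitrogen also stays within the scatter (a 1.1-fold higher number from compound 2 to compound 4 (0.05 log units; within the scatter)), so neither sulfonyl group separates from the unsubstituted amine. Pyridin-4-yl in place of pyridin-3-yl likewise gives no step beyond the scatter (a 1.1-fold higher number from compound 1 to compound 4 (0.03 log units; within the scatter)). Nothing available explains these small differences.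

The compounds shown leave open whether a nitrile or a methoxy group on this aromatic carbon would give a step beyond the scatter. They also leave open whether an acetyl group on the ring nitrogen would do so.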